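A few compounds are considered here, and "the series" means these few. Any claim that something is new, unique, unknown or untested is made for them only; others in the source may bear on it.

Measured so far in an assay on HEK293 cells for activation of Kir3.1/Kir3.2 (Homo sapiens), read by thallium flux; on this read-out lower numbers stand for an effect already at smaller amounts and higher numbers for an effect only at larger amounts of compound:
compound 1 `Cc1cc(NC(=O)Cn2nnc(-c3ccccc3)n2)n(C2CCCCC2)n1`: 96 nM
compound 2 `Cc1cc(NC(=O)Cn2nnc(-c3ccccc3)n2)n(CC2CCCCC2)n1`: 176 nM

Compound 1 shows the lowest of the two numbers, and its nearest neighbour is compound 2: the step of a 1.8-fold higher number from compound 1 to compound 2 (0.26 log units; within the scatter) lies within the scatter, so the two compounds are not told apart by this assay. Compound 3 `Cc1cc(NC(=O)Cn2nnc(-c3ccc(F)cc3)n2)n(C2CCCCC2)n1` differs from compound 1 by fluoro in place of hydrogen on an aromatic carbon. Among the compounds with values here, the only measured step, from compound 1 to compound 2, concerns the group on the aromatic nitrogen and leaves the phenyl ring untouched, so no measured step speaks directly to the change at hand. With nothing pointing either way, a step beyond the scatter is not expected. The estimate for compound 3 is therefore 100 nM, with a range from 40 nM to 250 nM. The expected step from compound 1 to compound 3 is a 1.0-fold higher number from compound 1 to compound 3 (0.02 log units; within the scatter).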

Compound 3, half-maximal effective concentration: 180 nM
For compound 3 the middle estimate is 1.8-fold (0.26 log units) below the measured one; the measured number falls inside the stated range.
By their numbers in this assay, from the lowest: compounds 1, 2 and 3 (each within the scatter of the next).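

Compound 3 is the first of the compounds shown to carry a change on the phenyl ring rather than on the group at the aromatic nitrogen. In this assay, going from phenyl to 4-fluorophenyl gives a 1.9-fold higher number from compound 1 to compound 3 (0.27 log units; within the scatter), so the assay does not tell the two compounds apart, and a fluoro can sit at this place on the ring without a difference that this read-out can resolve. No available measurement offers an explanation for this result.

Still open, on these data alone, is whether a chlorine, a methoxy group or an amine at the same place would also stay within the scatter, or whether one of them would clearly shift the number. Also open, as far as these compounds go, is whether fluoro on the ring would give a similar result alongside the cyclohexylmethyl group of compound 2.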